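Swapping the aryl group on the imine carbon of compound 1

The source may hold more compounds than are shown below. What is called first, only, known or untested is meant among the compounds shown, and "the series" means these compounds.

Compound 1 `COc1ccccc1/C=N/N(Cc1ccccc1)Cc1ccccc1` shows no measurable inhibition in an assay on liver (Sus scrofa) for inhibition of glucose-6-phosphatase catalytic subunit 1 (Homo sapiens), using microsomes; on this read-out lower numbers stand for stronger inhibition and higher numbers for weaker inhibition: compound 1 gives > 100000 nM, which is a limit of the assay rather than a number. Compound 2 `Clc1cc(Cl)cc(/C=N/N(Cc2ccccc2)Cc2ccccc2)c1` likewise gives only the limit > 100000 nM. Compound 3 `C(=N/N(Cc1ccccc1)Cc1ccccc1)\c1cccnc1` gives 3700 nM. Compound 1 thus stands at the limit of > 100000 nM in this assay, at which 2 of the 3 values shown sit, the weakest position the data can show.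

Compound 4 `O=[N+]([O-])c1ccc(/C=N/N(Cc2ccccc2)Cc2ccccc2)o1` differs from compound 1 by 5-nitrofuran-2-yl in place of 2-methoxyphenyl on a carbon with a double bond to nitrogen. Of the measured steps, a step that the two limits leave unreadable from compound 1 to compound 2 cannot be read, while an at least 27-fold lower number from compound 1 to compound 3 (1.43 log units; beyond the scatter), where a ring with a hetero atom also enters, was large. A step in the same direction is therefore expected, though of uncertain size; compound 4 is estimated at 20000 nM, between 3000 nM and 100000 nM, meaning an expected at least 5.0-fold lower number from compound 1 to compound 4 (0.69 log units; beyond the scatter).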

Compound 4, half-maximal inhibitory concentration: > 100000 nM
Compound 4 gave a limit, no number (the forecaster's own chance of this, stated with the estimate: 40%); middle value at least 5.0-fold (0.69 log units) away from the limit.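

On the carbon with a double bond to nitrogen, 5-nitrofuran-2-yl gives an at least 27-fold higher number from compound 3 to compound 4 (1.43 log units; beyond the scatter), so among these compounds a ring with a hetero atom is not enough on its own to give a readable value in this assay; pyridin-3-yl in compound 3 remains the exception. The steps from compound 1 and compound 2 to compound 4 join two limits and cannot be read. Compound 4 stays at the limit of the assay: the limit of > 100000 nM in this assay, at which 3 of the 4 values shown sit.

Still open, on these data alone, is whether furan-2-yl without the nitro group, or pyridin-4-yl, would give a readable value on this carbon.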